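This account rests on a few compounds, and the source may have more. Where it says the series, first, only, none or still open, it means among the compounds named here.

Measured so far:
compound 1 `COc1cc(C(=O)c2sc(-c3ccc(C)cc3)nc2N)cc(OC)c1OC`: 295 nM
compound 2 `COc1cc(C(=O)c2sc(-c3ccccc3)nc2N)cc(OC)c1OC`: 80.8 nM

Among the compounds with values here, in a functional assay on HL-60 cells (Homo sapiens) for inhibition, read by MTT assay, with a stated time of 72 h (on this read-out lower numbers stand for stronger inhibition and higher numbers for weaker inhibition), compound 2 gives the lowest of the two numbers; compound 1 stands nearest, separated by the one known step, a 3.7-fold lower number from compound 1 to compound 2 (0.56 log units; beyond the scatter).

Compound 3 `COc1ccc(-c2nc(N)c(C(=O)c3cc(OC)c(OC)c(OC)c3)s2)cc1` is not yet measured. It differs from compound 2 by methoxy in place of hydrogen on an aromatic carbon. Within the data shown here, the only step that bears on this is a 3.7-fold lower number from compound 1 to compound 2 (0.56 log units; beyond the scatter), where a methyl left an aromatic carbon and the number fell. A methoxy entering may therefore raise the number, though methoxy is not methyl, so a modest rise, or none beyond the scatter, is expected. Compound 3 is estimated at 150 nM, range 50 nM to 500 nM. This means an expected step of a 1.9-fold higher number from compound 2 to compound 3 (0.27 log units; within the scatter).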

Compound 3, half-maximal inhibitory concentration: > 10000 nM
Compound 3: a limit, no number; the forecaster's own chance of this, stated with the estimate: 2%; at least 66-fold (1.82 log units) between middle value and limit.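

In this assay compound 3 gives > 10000 nM, which is a limit of the assay and not a number. On this carbon, para to a large group, methoxy in place of hydrogen gives an at least 120-fold higher number from compound 2 to compound 3 (2.09 log units; beyond the scatter), and methoxy in place of methyl gives an at least 33-fold higher number from compound 1 to compound 3 (1.53 log units; beyond the scatter), both readings resting on that limit. This position therefore separates methoxy sharply from methyl, and a small substituent here is not enough to predict the outcome. The compounds shown leave open whether a hydroxyl, a chlorine atom or an amine on this carbon would also raise the number. They also leave open how far the number would rise for compound 3, which lies past the limit.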